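A Second Trifluoromethyl on the Anilide of Compound 1

The source may hold more compounds than are shown below. What is called first, only, known or untested is meant among the compounds shown, and "the series" means these compounds.

Measured so far:
compound 1 `O=C1CCCCC1S(=O)(=O)Nc1cccc(C(F)(F)F)c1` — 17%
compound 2 `O=C1CCCCC1S(=O)(=O)N1CCOCC1` — 11%
compound 3 `Cc1cc(F)ccc1NS(=O)(=O)C1CCCCC1=O` — -0.99%

Of the compounds shown here, three built on the shared core have been tested in a functional assay on HL-60 cells (Homo sapiens) for antiproliferative activity, read by MTT assay, tested at 100 ug/mL; on this read-out higher numbers stand for more inhibition at the one concentration tested (going by the name of the read-out) and lower numbers for less inhibition. Compound 1 gives 17%, the highest of the three numbers. Compound 2 gives 11%, which lies within the scatter of compound 1, so no order between the two can be read. Compound 3 gives -0.99%, a number beyond the scatter below compound 1. For the measured compounds named here, none of these pairs differs in a single place, so no clean structural step among the measured compounds is available.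

Compound 4 `O=C1CCCCC1S(=O)(=O)Nc1cc(C(F)(F)F)ccc1C(F)(F)F` is the next compound to be tested in this assay. It differs from compound 1 by trifluoromethyl in place of hydrogen on an aromatic carbon. Going by the values given here, with only three weak readings and no single-point step to lean on, the expected change from compound 1 to compound 4 in this assay is small, at most a modest rise, and it is not expected to go beyond the scatter. Compound 4 is therefore estimated to give 22%, with a range from 5% to 40%. The expected step of a number 5 percentage points higher from compound 1 to compound 4 (within the scatter) reflects that guarded view.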

Compound 4, a percentage reported as inhibition, at one concentration (the size of the read-out at that concentration, not a potency): 95.7%
Compound 4: middle estimate off by 73.7 percentage points, on the low side; the whole stated range lies below it.
By their numbers in this assay, from the lowest: compound 3; then compounds 2 and 1 (each within the scatter of the next); then compound 4.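

In this assay, for the compounds shown here, trifluoromethyl in place of hydrogen on an aromatic carbon, ortho to a large group and para to a trifluoromethyl group, gives a number 78.7 percentage points higher from compound 1 to compound 4 (beyond the scatter) as the first single-place step in this set. It shows that this position is far from indifferent: one added group separates a much lower number from the higher number of compound 4, at 95.7% at the one concentration tested. Nothing available bears on what lies behind this step.

On these data alone, it remains open whether a chlorine atom, a nitrile or a methoxy group in the same place would give a similar rise, or whether the new trifluoromethyl needs the one already present. A single-concentration percentage also leaves the potency of compound 4 undefined.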